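Adding a Second Fluorine to a Benzyl Group

The source may report more compounds than this note shows. Statements on the series, on what has been measured and on what is new or still open speak of the compounds shown alone.

Measured so far:
compound 1 `COC(=O)C[C@H](NC(=O)OC(C)(C)C)C(=O)N(Cc1ccccc1)C1(C(=O)NCc2ccccc2)CCN(Cc2ccccc2)CC1`: > 100000 nM
compound 2 `COC(=O)C[C@H](NC(=O)OC(C)(C)C)C(=O)N(Cc1cccc(F)c1)C1(C(=O)NCc2ccccc2)CCN(Cc2ccccc2)CC1`: 47000 nM
compound 3 `COC(=O)C[C@H](NC(=O)OC(C)(C)C)C(=O)N(Cc1ccc(F)cc1)C1(C(=O)NCc2ccccc2)CCN(Cc2cccc(F)c2)CC1`: 84000 nM

In an ADME assay on MDCK cells (Canis lupus familiaris) for cytotoxicity, read by microscopy, with a stated time of 72 h (on this read-out higher numbers stand for lower toxicity in this test and lower numbers for higher toxicity in this test), compound 1 gives only a limit, > 100000 nM. Compound 2 carries fluoro in place of hydrogen on an aromatic carbon and sits at 47000 nM in this assay, a step of an at least 2.1-fold lower number from compound 1 to compound 2 (0.32 log units; beyond the scatter); the size cannot be told more closely because compound 1 sits at the limit of > 100000 nM in this assay, at which 1 of the 3 values shown sits. How the core of compound 3 differs from that of compound 1 is not broken down here; in this assay compound 3 gives 84000 nM, within the scatter of compound 2.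

Compound 4 `COC(=O)C[C@H](NC(=O)OC(C)(C)C)C(=O)N(Cc1ccc(F)cc1)C1(C(=O)NCc2ccccc2)CCN(Cc2cc(F)cc(F)c2)CC1` is not yet measured. It carries fluoro in place of hydrogen on an aromatic carbon, the same kind of change as from compound 1 to compound 2, though here the place is meta to a fluoro group. Resting on that earlier step, compound 4 is expected to give 50000 nM in this assay, between 20000 nM and 120000 nM, an estimated step of a 1.7-fold lower number from compound 3 to compound 4 (0.23 log units; within the scatter).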

Compound 4, minimum cytotoxic concentration: 100000 nM
Compound 4: middle estimate off by 2.0-fold (0.30 log units), on the low side; measured number inside the range.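

In this assay, going from 3-fluorobenzyl to 3,5-difluorobenzyl gives a 1.2-fold higher number from compound 3 to compound 4 (0.08 log units; within the scatter), so on this core the added fluoro group makes no difference beyond the scatter. Set beside the same change on the other core, this result neither confirms nor rules out that the change carries over from one core to another: the same change on two cores in this assay, an at least 2.1-fold lower number (0.32 log units; beyond the scatter) from compound 1 to compound 2 and a 1.2-fold higher number (0.08 log units; within the scatter) from compound 3 to compound 4; the limit leaves it open whether they differ. Compound 1 gives only a limit, not a number: the limit of > 100000 nM in this assay, at which 1 of the 4 values shown sits.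

The compounds shown leave open whether a chloro or methoxy group in place of this fluoro group would give a similar reading. They also leave open how a carboxylic acid in place of the methyl ester would read in this test.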